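A few compounds are considered here, and "the series" means these few. Any claim that something is new, unique, unknown or untested is made for them only; others in the source may bear on it.

Measured so far:
- compound 1, `CN1C(=S)N(C2CCCCC2)C(=O)/C1=C/c1ccc(N(C)C)cc1`: 12300 nM
- compound 2, `CN1C(=S)N(c2ccc3c(c2)CCC3)C(=O)/C1=C/c1ccc(O)cc1O`: 6580 nM

In an assay for inhibition of NADPH oxidase 1 (Homo sapiens), read by chemiluminescence (a lower number here means a stronger inhibitor, a higher number a weaker inhibitor), compound 1 gives 12300 nM and compound 2 gives 6580 nM; compound 2 holds the lower of the two numbers, but the gap to compound 1 lies within the scatter, so no order between them is claimed. Compound 3, `CN1C(=S)N(c2ccc3c(c2)CCC3)C(=O)/C1=C/c1ccc(N(C)C)cc1`, is not yet measured. Relative to compound 2 the change is 4-(dimethylamino)phenyl in place of 2,4-dihydroxyphenyl on a double-bonded chain carbon bound to a double-bonded ring carbon; the rest of the molecule, including the group on the thiourea nitrogen, stays as in compound 2. Compound 1 already carries the entering 4-(dimethylamino)phenyl with a different group on that nitrogen, and its value sits within the scatter of compound 2. On this basis the step is expected to be small, with no direction beyond the scatter: a 1.4-fold higher number from compound 2 to compound 3 (0.16 log units; within the scatter). For compound 3 in this assay the estimate is 9500 nM, with a range from 3000 nM to 30000 nM.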

Compound 3, inhibition constant: 8040 nM
Beside the measured number, compound 3's estimate is 1.2-fold (0.07 log units) above it; the measured number falls inside the stated range.
By their numbers in this assay, from the lowest: compounds 2, 3 and 1 (each within the scatter of the next).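

In this assay, among these compounds, 4-(dimethylamino)phenyl in place of 2,4-dihydroxyphenyl on a double-bonded chain carbon bound to a double-bonded ring carbon gives a 1.2-fold higher number from compound 2 to compound 3 (0.09 log units; within the scatter) and so stays within the scatter, even though the hydrogen-bond donors of the leaving group have no counterpart in the entering one. With 4-(dimethylamino)phenyl held constant, 2,3-dihydro-1H-inden-5-yl in place of cyclohexyl on an amide-type nitrogen in a ring gives a 1.5-fold lower number from compound 1 to compound 3 (0.18 log units; within the scatter) and also stays within the scatter, so neither change separates the compounds in this assay. No evidence on the cause of either result is available.

On these data alone, whether any group at the first place, such as 4-carboxyphenyl, would give a step beyond the scatter remains open. The same holds for an amide-type nitrogen carrying a longer alkyl chain or an aminoalkyl chain.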